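Fluoro for Methyl on a Sulfonamide Core

The source may report more compounds than this note shows. Statements on the series, on what has been measured and on what is new or still open speak of the compounds shown alone.

Compound 1 `CS(=O)(=O)Nc1ccc(O)c2c1CCCC2c1c[nH]cn1` carries a hydroxy group on its aromatic ring. In an assay on isolated protein for binding affinity to Alpha-1D adrenergic receptor (Rattus norvegicus), read by radioligand binding (on this read-out lower numbers stand for stronger inhibition and higher numbers for weaker inhibition), compound 1 gives < 10000 nM, which is a limit of the assay and not a number. Compound 2 `COc1ccc(NS(C)(=O)=O)c2c1C(c1c[nH]cn1)CCC2` has a methoxy group in that place, and in this assay compound 2 gives < 10000 nM, again a limit rather than a number. Within the data shown here, compound 3 `Cc1ccc(NS(C)(=O)=O)c2c1C(c1c[nH]cn1)CCC2` bears a methyl group there; in this assay compound 3 gives 2690 nM, the only true number among the three values shown. The steps a step that the two limits leave unreadable from compound 1 to compound 2, a step that the limit leaves unreadable from compound 1 to compound 3 and a step that the limit leaves unreadable from compound 2 to compound 3 cannot be sized because two of the values rest on (the limit of < 10000 nM in this assay, at which 2 of the 3 values shown sit).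

Compound 4 `CS(=O)(=O)Nc1ccc(F)c2c1CCCC2c1c[nH]cn1` has not yet been measured. It differs from compound 3 by fluoro in place of methyl on an aromatic carbon. No measured step among these compounds can be read, so nothing points to a shift in either direction. Compound 4 is therefore expected to give an inhibition constant of about 3000 nM, with a range from 1000 nM to 10000 nM. The expected step of a 1.1-fold higher number from compound 3 to compound 4 (0.05 log units; within the scatter) stays within the usual scatter.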

Compound 4, inhibition constant: 3020 nM
Beside the measured number, compound 4's estimate is 1.0-fold (0.00 log units) below it, within the range that was stated.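

In this assay, fluoro in place of methyl on this aromatic carbon, para to a methanesulfonamido group, gives a 1.1-fold higher number from compound 3 to compound 4 (0.05 log units; within the scatter). This is the first step among these compounds that can be sized, and it shows that at this position one of these two groups can take the place of the other with no change beyond the scatter. The steps to compound 4 from compound 1 and from compound 2 cannot be read, so fluoro cannot be compared with hydroxy or methoxy: the limit of < 10000 nM in this assay, at which 2 of the 4 values shown sit.

From the compounds shown here alone, whether chloro, an amine or a carboxylic acid on this aromatic carbon would give a number that differs beyond the scatter stays open. So does the effect on the number in this assay of a longer chain in place of the methyl of the methanesulfonamido group.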